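Methyl in Place of Chloro on a Second Core

The source may hold more compounds than are shown below. What is called first, only, known or untested is meant among the compounds shown, and "the series" means these compounds.

Compound 1 `CC(=O)OC[C@H]1O[C@@H](n2c(SCc3cc4cc(Cl)ccc4oc3=O)nc3cncnc32)[C@H](OC(C)=O)[C@@H]1OC(C)=O` and compound 2 `CC(=O)OC[C@H]1O[C@@H](n2c(SCc3cc4cc(C)ccc4oc3=O)nc3cncnc32)[C@H](OC(C)=O)[C@@H]1OC(C)=O` share one core; compound 3 `O=c1oc2ccc(Cl)cc2cc1CSc1nc2cncnc2n1[C@@H]1O[C@H](CO)[C@@H](O)[C@H]1O` and the unmeasured compound 4 `Cc1ccc2oc(=O)c(CSc3nc4cncnc4n3[C@@H]3O[C@H](CO)[C@@H](O)[C@H]3O)cc2c1` share another. The difference between the two cores is not broken down here. In a functional assay on Huh-5-2 cells (Homo sapiens) for cytotoxicity, read by microscopy (on this read-out lower numbers stand for higher toxicity in this test and higher numbers for lower toxicity in this test), compound 1 gives 7500 nM and compound 2 gives 16000 nM; the change between them is methyl in place of chloro on an aromatic carbon and it made the step of a 2.1-fold higher number from compound 1 to compound 2 (0.33 log units; beyond the scatter). Compound 3 gives 37000 nM in this assay, the highest of the three numbers. Compound 4 carries the same change on its own core: methyl in place of chloro on an aromatic carbon. If this change moves the number as before, compound 4 is expected to show a 2.1-fold higher number from compound 3 to compound 4 (0.32 log units; beyond the scatter), an expectation resting on a 2.1-fold higher number from compound 1 to compound 2 (0.33 log units; beyond the scatter). Compound 4 is thus estimated at 78000 nM, with a likely range from 35000 nM to 180000 nM.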

Compound 4, half-maximal cytotoxic concentration: 46000 nM
Beside the measured number, compound 4's estimate is 1.7-fold (0.23 log units) above it; the range from low to high includes it.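

In this assay, putting methyl in place of chloro on the second core gives a 1.2-fold higher number from compound 3 to compound 4 (0.09 log units; within the scatter), a step too small to separate the two compounds. Set beside the step on the first core, the change does not behave measurably differently from one core to the other: the same change on two cores in this assay, a 2.1-fold higher number (0.33 log units; beyond the scatter) from compound 1 to compound 2 and a 1.2-fold higher number (0.09 log units; within the scatter) from compound 3 to compound 4, 1.7-fold (0.23 log units) apart, within the scatter of two such steps. This shows that the two steps are compatible, but two pairs cannot show that the change carries over to other cores in this series, and they do not say why the number moves.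

The compounds shown carry only chloro or methyl at this place on the ring. On these data alone, what an amine or a carboxylic acid there would do to the number remains open.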